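The source may hold more compounds than are shown below. What is called first, only, known or untested is meant among the compounds shown, and "the series" means these compounds.

Compound 1, `CCOc1ccc2nc(Cl)c(/C=N/NC(=O)c3cc4cc([N+](=O)[O-])ccc4oc3=O)cc2c1`, was tested in a functional assay on PANC-1 cells (Homo sapiens) for antiproliferative activity, read by fluorescence and resazurin assay, with a stated time of 48 h (a higher number here means a weaker inhibitor, a lower number a stronger inhibitor), where compound 1 gives 10500 nM. Compound 2, `CCOc1ccc2nc(Cl)c(/C=N/NC(=O)c3cc4cc(Br)ccc4oc3=O)cc2c1`, carries the change bromo in place of nitro on an aromatic carbon on the core of compound 1, and in this assay compound 2 gives 17000 nM. The step made by this change was a 1.6-fold higher number from compound 1 to compound 2 (0.21 log units; within the scatter).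

Compound 3, `Cc1noc(NS(=O)(=O)c2ccc(NC(=O)c3cc4cc([N+](=O)[O-])ccc4oc3=O)cc2)c1C`, has a different core; the difference between the two cores is not broken down here. In this assay compound 3 gives 11900 nM, a number within the scatter of both compound 1 and compound 2.

Compound 4, `Cc1noc(NS(=O)(=O)c2ccc(NC(=O)c3cc4cc(Br)ccc4oc3=O)cc2)c1C`, has not yet been measured. Within the data shown here, it differs from compound 3 by bromo in place of nitro on an aromatic carbon, which is the same change as the one that turned compound 1 into compound 2. Because the earlier step of a 1.6-fold higher number from compound 1 to compound 2 (0.21 log units; within the scatter) stayed within the scatter, the expected step is a 1.3-fold higher number from compound 3 to compound 4 (0.13 log units; within the scatter), a small shift in the same direction. On that basis compound 4 is estimated at 16000 nM, with a likely range from 8000 nM to 32000 nM.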

Compound 4, half-maximal inhibitory concentration: 28700 nM
Estimate against measurement, compound 4: 1.8-fold (0.25 log units) below, and the stated range covers the measured number.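

In this assay, bromo in place of nitro on the second core gives a 2.4-fold higher number from compound 3 to compound 4 (0.38 log units; beyond the scatter), a modest step that, unlike the earlier one, lies beyond the scatter. Set side by side, the two steps point the same way and differ by no more than repeated measurements would allow: the same change on two cores in this assay, a 1.6-fold higher number (0.21 log units; within the scatter) from compound 1 to compound 2 and a 2.4-fold higher number (0.38 log units; beyond the scatter) from compound 3 to compound 4, 1.5-fold (0.17 log units) apart, within the scatter of two such steps. The change therefore carries over from the core of compound 1 to the core of compound 3 in direction and, as far as these data can tell, in size, but two cores are a small sample, and the pairs show neither why the number rises nor whether a third core would behave alike.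

Among the compounds shown, this place on the aromatic ring carries only nitro or bromo, so how an amine, a methoxy group or a carboxylic acid there would read in this assay remains open. Whether any such group would shift the number equally on both cores is open too.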